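A Fluorine on the Anilide Ring of Compound 4

The source may hold more compounds than are shown below. What is called first, only, known or untested is meant among the compounds shown, and "the series" means these compounds.

Compound 1 `O=C(NCc1cn(Cc2ccc3oc(-c4ccccc4)cc(=O)c3c2)nn1)c1ccccc1` gives 15600 nM
Compound 2 `O=C(CCc1cn(Cc2ccc3oc(-c4ccccc4)cc(=O)c3c2)nn1)Nc1ccc(Cl)cc1` gives 15600 nM
Compound 3 `O=C(CCc1cn(Cc2ccc3oc(-c4ccccc4)cc(=O)c3c2)nn1)Nc1ccccc1` gives 15600 nM

In an assay on isolated protein for inhibition of Amine oxidase [flavin-containing] B (Homo sapiens), read by fluorescence and spectrophotometry (on this read-out lower numbers stand for stronger inhibition and higher numbers for weaker inhibition), compound 3 stands level with compound 1 and compound 2: the steps of no change at the digits printed from compound 1 to compound 3 (within the scatter) and no change at the digits printed from compound 2 to compound 3 (within the scatter) both lie within the scatter, and so does no change at the digits printed from compound 1 to compound 2 (within the scatter). Nothing in these three numbers separates one amide arrangement from another.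

Compound 4 `O=C(CCc1cn(Cc2ccc3oc(-c4ccccc4)cc(=O)c3c2)nn1)Nc1ccc(F)cc1` is compound 3 with fluoro in place of hydrogen on an aromatic carbon, on an aromatic carbon of the six-membered carbon ring, para to a large group. For the measured compounds named here, the one measured step that speaks to this place is the removal of chloro in no change at the digits printed from compound 2 to compound 3 (within the scatter), which left the number unchanged within the scatter. A halogen at that position has therefore shown no effect so far, and the entering fluoro is expected to behave alike: the step of no change at the digits printed from compound 3 to compound 4 (within the scatter) is expected to fall within the scatter, in no particular direction. For compound 4 the estimate in this assay is 15600 nM, with a range from 7000 nM to 35000 nM.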

Compound 4, half-maximal inhibitory concentration: 15600 nM
Estimate against measurement, compound 4: no gap at the digits printed, and the stated range covers the measured number.
By their numbers in this assay, from the lowest: compounds 1, 2, 3 and 4 (each within the scatter of the next).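

In this assay, fluoro now joins chloro and hydrogen on an aromatic carbon para to a large group, and the three cannot be told apart at this place: swapping in fluoro for hydrogen gives no change at the digits printed from compound 3 to compound 4 (within the scatter), and swapping in fluoro for chloro gives no change at the digits printed from compound 2 to compound 4 (within the scatter). The fluorinated anilide also stands level with the benzamido arrangement, with no change at the digits printed from compound 1 to compound 4 (within the scatter). No measurement is available to explain this flat result.

The compounds shown leave open whether an amine or a carboxylic acid on that aromatic carbon, or a longer chain carrying the amide, would move the number at all. They also leave open whether any change to the shared core would separate these compounds in this assay.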